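The source may report more compounds than this note shows. Statements on the series, on what has been measured and on what is new or still open speak of the compounds shown alone.

Compound 1 `NC(=S)N/N=C/c1ccc2ccccc2n1` carries a plain hydrogen on the amide-type nitrogen of the shared core. In a functional assay on SGC-7901 cells (Homo sapiens) for antiproliferative activity, read by sulforhodamine B assay, with a stated time of 72 h (a higher number here means a weaker inhibitor, a lower number a stronger inhibitor), compound 1 gives 32700 nM. Compound 2 `Cc1ccccc1NC(=S)N/N=C/c1ccc2ccccc2n1` places a 2-methylphenyl on that nitrogen. In this assay compound 2 reaches only a limit of the measurement, > 100000 nM. Compound 3 `Fc1ccccc1NC(=S)N/N=C/c1ccc2ccccc2n1` places a 2-fluorophenyl on the same nitrogen. In this assay compound 3 also stands at a limit, > 100000 nM, so no number is known for it. Two of the three values shown sit at that boundary (the limit of > 100000 nM in this assay, at which 2 of the 3 values shown sit). The measured steps read an at least 3.0-fold higher number from compound 1 to compound 2 (0.48 log units; beyond the scatter) and an at least 3.0-fold higher number from compound 1 to compound 3 (0.48 log units; beyond the scatter), so putting either aryl group on the nitrogen weakened inhibition at least modestly. Between the two aryl compounds, a step that the two limits leave unreadable from compound 2 to compound 3.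

Compound 4 `S=C(N/N=C/c1ccc2ccccc2n1)Nc1ccc(Cl)cc1` differs from compound 3 by one change: 4-chlorophenyl in place of 2-fluorophenyl on an amide-type nitrogen. Both steps that bear on it, from compound 1 to compound 2 and from compound 1 to compound 3, show that an aryl group on this nitrogen leaves the number at the limit, and compound 4 keeps an aryl group there. The step of a number no higher from compound 3 to compound 4 (the limit leaves the size open) is therefore expected to be none beyond the scatter. Compound 4 is estimated at 100000 nM, within 30000 nM to 300000 nM, most likely again reported only as a limit.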

Compound 4, half-maximal inhibitory concentration: 87600 nM
For compound 4 the middle estimate is 1.1-fold (0.06 log units) above the measured one; low and high end bracket the measured number.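

In this assay, compound 4 is the only aryl compound shown that gives a number rather than a limit, so the price of an aryl group on this amide-type nitrogen can now be sized in one case: a 2.7-fold higher number from compound 1 to compound 4 (0.43 log units; beyond the scatter), a modest weakening that lies beyond the scatter. Against the other two aryl compounds, the result reads as an at least 1.1-fold lower number from compound 3 to compound 4 (0.05 log units; that floor lies within the scatter) and an at least 1.1-fold lower number from compound 2 to compound 4 (0.05 log units; that floor lies within the scatter); both floors lie within the scatter, so no order among 4-chlorophenyl, 2-fluorophenyl and 2-methylphenyl can be claimed. The true size of these two steps cannot be read, because compound 2 and compound 3 stand only at a limit: the limit of > 100000 nM in this assay, at which 2 of the 4 values shown sit.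

As far as these compounds go, what stays open is whether a step of this size holds for aryl groups in general, as compound 4 provides the only readable case. From the compounds shown here alone, it is also open how a methyl group, a longer chain, or a phenyl ring carrying an amine or a carboxylic acid would compare with the plain hydrogen of compound 1 on this nitrogen.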